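Naphthalen-2-yl in place of methylsulfonylphenyl on the shared core

The source may report more compounds than this note shows. Statements on the series, on what has been measured and on what is new or still open speak of the compounds shown alone.

Compound 1 `Cc1ccc(-c2csc(N3N=C(c4ccc(N5CCCCC5)cc4)CC3c3ccc(Cl)cc3)n2)cc1`: in a functional assay on MCF7 cells (Homo sapiens) for antiproliferative activity, read by MTT assay, with a stated time of 72 h (on this read-out higher numbers stand for weaker inhibition and lower numbers for stronger inhibition), compound 1 gives > 100000 nM, a limit of the assay.
Compound 2 `COc1ccc(-c2csc(N3N=C(c4ccc(N5CCCCC5)cc4)CC3c3ccc(Cl)cc3)n2)cc1`: compound 2 gives > 100000 nM, again a limit.
Compound 3 `CS(=O)(=O)c1ccc(-c2csc(N3N=C(c4ccc(N5CCCCC5)cc4)CC3c3ccc(Cl)cc3)n2)cc1`: compound 3 gives > 100000 nM, also a limit.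

Going by the values given here, compound 3 therefore stands at the limit where every value so far sits (the limit of > 100000 nM in this assay, at which 3 of the 3 values shown sit). The steps among these compounds, a step that the two limits leave unreadable from compound 1 to compound 2, a step that the two limits leave unreadable from compound 1 to compound 3 and a step that the two limits leave unreadable from compound 2 to compound 3, are unreadable, since both ends of each are limits. Compound 4 `Clc1ccc(C2CC(c3ccc(N4CCCCC4)cc3)=NN2c2nc(-c3ccc4ccccc4c3)cs2)cc1` differs from compound 3 by naphthalen-2-yl in place of 4-(methylsulfonyl)phenyl on an aromatic carbon. Among the compounds with values here, no measured step bears directly on this exchange; the measured variations at the same position all left the read-out at the limit. The step from compound 3 to compound 4 is expected to be a number no higher from compound 3 to compound 4 (the limit leaves the size open), nothing beyond the scatter. Compound 4 is estimated at 100000 nM, within 30000 nM to 300000 nM.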

Compound 4, half-maximal inhibitory concentration: > 100000 nM
Compound 4 gave a limit, no number; the forecaster's own chance of this, stated with the estimate: 70%; the middle value sits exactly at the limit.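

Compound 4 also gives only a limit, so its steps from compound 1, compound 2 and compound 3 cannot be read. The compounds shown leave open how these four rank and whether any group at this position gives a measurable value: the limit of > 100000 nM in this assay, at which 4 of the 4 values shown sit.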